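This account rests on a few compounds, and the source may have more. Where it says the series, first, only, none or still open, it means among the compounds named here.

In a functional assay on HeLa cells (Homo sapiens) for inhibition, read by sulforhodamine B assay (on this read-out lower numbers stand for stronger inhibition and higher numbers for weaker inhibition), compound 1 `O=C1C=C(NCc2ccccc2)C(=O)c2c1nc1n2[C@H]2OC[C@@H](O)[C@H]2OC1` gives > 8000 nM, which is a limit and not a number. Going by the values given here, compound 2 `COc1ccccc1NC1=CC(=O)c2nc3n(c2C1=O)[C@H]1OC[C@@H](O)[C@H]1OC3` gives 2950 nM, the only actual number so far. The next change leads to compound 3 `O=C1C=C(Nc2ccc(Br)cc2)C(=O)c2c1nc1n2[C@H]2OC[C@@H](O)[C@H]2OC1`: 4-bromophenyl in place of 2-methoxyphenyl on an amine nitrogen. Among the compounds with values here, one measured step bears on this nitrogen: an at least 2.7-fold lower number from compound 1 to compound 2 (0.43 log units; beyond the scatter), its size bounded on one side by the limit of > 8000 nM in this assay, at which 1 of the 2 values shown sits. That step replaced benzyl, whereas this one replaces 2-methoxyphenyl itself, so it offers no direction for the new change. A shift beyond the scatter in this assay is therefore not expected, and neither direction is favoured. The expected change is a 1.2-fold lower number from compound 2 to compound 3 (0.07 log units; within the scatter), which would lie within the scatter. For compound 3 the estimated value is 2500 nM, with an expected range of 800 nM to 8000 nM.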

Compound 3, half-maximal inhibitory concentration: 3830 nM
Compound 3: the middle estimate sits 1.5-fold (0.19 log units) below what was measured; low and high end bracket the measured number.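

In this assay, the swap on the amine nitrogen leaves 2-methoxyphenyl and 4-bromophenyl indistinguishable: a 1.3-fold higher number from compound 2 to compound 3 (0.11 log units; within the scatter). Against benzyl, the 4-bromophenyl compound also lies beyond the scatter, an at least 2.0-fold lower number from compound 1 to compound 3 (0.31 log units; beyond the scatter), so the earlier step away from benzyl is no longer tied to 2-methoxyphenyl alone, and both compounds with a phenyl ring placed directly on this nitrogen read lower than compound 1. Compound 1 carries a limit and not a number, which leaves the size of both steps from it bounded on one side only: the limit of > 8000 nM in this assay, at which 1 of the 3 values shown sits.

The compounds shown do not tell whether the methoxy or bromine substituent contributes anything, as unsubstituted phenyl on this nitrogen is not among them. From the compounds shown here alone, how a simple alkyl chain such as n-butyl, or a phenyl ring bearing a carboxylic acid, would read also remains open.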